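Halogen swap on the aryl ring: cytotoxicity outlook

The source may report more compounds than this note shows. Statements on the series, on what has been measured and on what is new or still open speak of the compounds shown alone.

Within the data shown here, compound 2 `O=C1CSC(c2ccc(F)cc2)N1CCN1CCCCC1` gives 100% in an ADME assay on Vero cells (Chlorocebus sabaeus) for cytotoxicity, read by neutral red uptake, tested at 49 ug/mL (a higher number here means a weaker effect of the compound at the concentration tested, a lower number a stronger effect), the highest of the two numbers so far. Among the measured compounds shown here, compound 1 `O=C1CSC(c2ccc(Cl)cc2)N1CCN1CCCCC1` gives 84% in this assay, and the step of a number 16 percentage points higher from compound 1 to compound 2 (beyond the scatter) is the only measured comparison. Compound 3 `O=C1CSC(c2ccccc2Cl)N1CCN1CCCCC1` carries 2-chlorophenyl in place of 4-fluorophenyl on a saturated ring carbon. For the measured compounds named here, the measured step covers only chloro against fluoro, and in the opposite direction; the rest of the change has no measured counterpart, so the expected direction is downward, about the size of that step, with wide uncertainty. Compound 3 is therefore expected at 85%, between 68% and 100%, a step of a number 15 percentage points lower from compound 2 to compound 3 (beyond the scatter).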

Compound 3, a percentage reported as activity, at one concentration (the size of the read-out at that concentration, not a potency): 100%
Estimate against measurement, compound 3: 15 percentage points below; the measured number falls inside the stated range.
By their numbers in this assay, from the lowest: compound 1; then compounds 2 and 3 (each within the scatter of the next).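

In this assay, 2-chlorophenyl in place of 4-fluorophenyl on the saturated ring carbon gives no change at the digits printed from compound 2 to compound 3 (within the scatter) and so shows that a chlorine on the aryl ring need not lower the number. With chlorine kept, 2-chlorophenyl in place of 4-chlorophenyl gives a number 16 percentage points higher from compound 1 to compound 3 (beyond the scatter) and so ties the lower number of compound 1 to the 4-chlorophenyl group, not to chlorine as such. Nothing available explains either step. Still open, as far as these compounds go, is whether a nitrile or a carboxylic acid on the phenyl ring would keep the number of compound 3.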